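From tert-Butyl to Bromo on the Aromatic Ring

This account rests on a few compounds, and the source may have more. Where it says the series, first, only, none or still open, it means among the compounds named here.

Of the compounds shown here, two sharing one core have been tested in a functional assay on the whole organism (Hindlimb) for inhibition, with Mus musculus as the target, with a stated time of 0.5 h; a higher number here means that more compound is needed for the effect, a lower number that less compound is needed. Compound 1 `Cc1cccc(C(=O)NN2C(=O)NC3(CC3(C)C)C2=O)c1` gives 100 mg/kg in this assay. Compound 2 `CC(C)(C)c1ccc(C(=O)NN2C(=O)NC3(CC3(C)C)C2=O)cc1` gives 30 mg/kg in this assay, the lower of the two numbers; its gap to compound 1 is beyond the usual scatter, so compound 2 needs less material for the effect. Compound 3 `CC1(C)CC12NC(=O)N(NC(=O)c1ccc(Br)cc1)C2=O` differs from compound 2 in one place: bromo in place of tert-butyl on an aromatic carbon. For the measured compounds named here, no measured pair shows this particular exchange, so the size of its effect is open. Going by the values given here, because compound 2 gives 30 mg/kg and compound 1 gives 100 mg/kg, the numbers so far span a narrow band, and the expectation for compound 3 stays close to it. A modest rise in the dose needed is expected, a step of a 1.7-fold higher number from compound 2 to compound 3 (0.22 log units; within the scatter), so compound 3 is estimated at 50 mg/kg, with a range from 20 mg/kg to 150 mg/kg.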

Compound 3, minimum effective dose: 300 mg/kg
Compound 3: middle estimate off by 6.0-fold (0.78 log units), on the low side, and the stated range ends below it.
By their numbers in this assay, from the lowest: compound 2; then compound 1; then compound 3.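

Swapping tert-butyl for bromo on this aromatic carbon is far from a neutral exchange in this assay: the dose needed rises, a step of a 10-fold higher number from compound 2 to compound 3 (1.00 log units; beyond the scatter). Compound 3 also compares poorly with the methyl-bearing compound, since 4-bromophenyl in place of 3-methylphenyl on the carbonyl carbon gives a step of a 3.0-fold higher number from compound 1 to compound 3 (0.48 log units; beyond the scatter), which leaves compound 3 with the highest number of the three. Nothing available explains why the dose rises with this exchange.

As far as these compounds go, with only tert-butyl and bromo compared at this position, it remains open how an amine, a methoxy group or a carboxylic acid would behave there. Also open, from the compounds shown here alone, is whether a longer carbon chain in place of tert-butyl would keep the dose as low as that of compound 2.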